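Trading a Phenyl for a Methyl in Compound 4

The source may hold more compounds than are shown below. What is called first, only, known or untested is meant among the compounds shown, and "the series" means these compounds.

In a functional assay for agonist activity at Free fatty acid receptor 1 (Homo sapiens) (on this read-out lower numbers stand for an effect already at smaller amounts and higher numbers for an effect only at larger amounts of compound), compound 1 `O=C(O)CCc1ccc(NCc2ccc(-c3ccccc3)cc2)cc1` gives 251 nM. Among the three measured compounds it holds the second highest number: compound 2 `O=C(O)C1CC1c1ccc(NCc2ccc(-c3ccccc3)cc2)cc1` gives 39.8 nM, while compound 3 `O=C(O)CCCc1ccc(NCc2ccc(-c3ccccc3)cc2)cc1` gives 1580 nM. Every measured step alters the acid-bearing chain on the shared core: a 6.3-fold lower number from compound 1 to compound 2 (0.80 log units; beyond the scatter), a 6.3-fold higher number from compound 1 to compound 3 (0.80 log units; beyond the scatter), and a 40-fold higher number from compound 2 to compound 3 (1.60 log units; beyond the scatter). Compound 4 `Cc1ccc(CNc2ccc(CCC(=O)O)cc2)cc1` differs from compound 1 at a different place: methyl in place of phenyl on an aromatic carbon. For the measured compounds named here, none of the measured steps touches this part of the molecule, so they give no direct guide to the size or direction of the change; they show only that single alterations to this core move the read-out by modest to large amounts. An entire ring is removed here. A sizable shift is expected rather than none. Compound 4 is therefore estimated at 2500 nM, with a range from 500 nM to 12000 nM. That estimate means a 10-fold higher number from compound 1 to compound 4 (1.00 log units; beyond the scatter) is expected, carrying wide uncertainty.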

Compound 4, half-maximal effective concentration: 3980 nM
Estimate against measurement, compound 4: 1.6-fold (0.20 log units) below; the range from low to high includes it.
By their numbers in this assay, from the lowest: compound 2; then compound 1; then compound 3; then compound 4.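

In this assay, for the compounds shown here, methyl in place of phenyl gives a 16-fold higher number from compound 1 to compound 4 (1.20 log units; beyond the scatter) and is the first measured step at this position, so the read-out depends on this part of the molecule as well as on the acid-bearing chain. Neither group carries a hydrogen-bond donor or acceptor, so the counted difference here is the six-membered aromatic ring and its heavy atoms, and removing them leaves a higher number. Nothing shown accounts for the size of this shift.

On these data alone, whether a chlorine, an ethyl or a pyridyl group at this place would bring the number closer to that of compound 1 remains open. As far as these compounds go, it is also open whether the 2-carboxycyclopropyl chain of compound 2 would keep its lower number with methyl in place of phenyl.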